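Adding an Aryl Amide Back onto the Chain of Compound 3

The source may hold more compounds than are shown below. What is called first, only, known or untested is meant among the compounds shown, and "the series" means these compounds.

Compound 1, `Cn1c(Cc2nn(C)c(=O)c3ccccc23)nnc1SCCCCCCCC(=O)Nc1ccc(I)cc1`, gives 1300 nM in an assay on isolated protein (Mus musculus) for inhibition of IL15-IL15 receptor (Homo sapiens), read by resazurin assay, with stated times of 30 min and 2.5 days; on this read-out lower numbers stand for stronger inhibition and higher numbers for weaker inhibition.
Compound 2, `CCCOc1ccc(NC(=O)CCCCCCCSc2nnc(Cc3nn(C)c(=O)c4ccccc34)n2C)cc1`, gives 1600 nM in this assay.
Compound 3, `CCCCCCCCCCSc1nnc(Cc2nn(C)c(=O)c3ccccc23)n1C`, gives 7600 nM in this assay.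

Compound 3 stands at the highest number of the three in this assay, beyond the scatter from both compound 2 and compound 1. Compound 4, `Cc1ccc(NC(=O)CCCCCCCSc2nnc(Cc3nn(C)c(=O)c4ccccc34)n2C)c(Cl)c1`, is not yet measured; it differs from compound 3 by (2-chloro-4-methylphenyl)carbamoyl in place of propyl on a saturated chain carbon, seven bonds along the chain from a sulfur. Among the measured compounds shown here, the step that bears on this is the one from compound 1 to compound 3, where the opposite change, removing the aryl amide, gave a 5.8-fold higher number from compound 1 to compound 3 (0.77 log units; beyond the scatter). The step from compound 1 to compound 2 shows a 1.2-fold higher number from compound 1 to compound 2 (0.09 log units; within the scatter), so swapping the substituent on that ring from iodo to propoxy changed little. Reattaching an aryl amide, now with chloro and methyl on the ring, is therefore expected to lower the number for compound 4 to about a 5.4-fold lower number from compound 3 to compound 4 (0.73 log units; beyond the scatter), landing it near compound 1 and compound 2. The estimate for compound 4 in this assay is 1400 nM, expected between 700 nM and 3000 nM.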

Compound 4, half-maximal inhibitory concentration: 2300 nM
Compound 4: the middle estimate sits 1.6-fold (0.22 log units) below what was measured; the measured number falls inside the stated range.
By their numbers in this assay, from the lowest: compounds 1, 2 and 4 (each within the scatter of the next); then compound 3.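

In this assay, among the compounds shown here, placing (2-chloro-4-methylphenyl)carbamoyl on the saturated chain carbon, seven bonds along the chain from a sulfur, gives a 3.3-fold lower number from compound 3 to compound 4 (0.52 log units; beyond the scatter) and so shows directly that adding an aryl amide to the chain of compound 3 lowers the number, where the earlier compounds showed only the effect of removing one. The ring on the amide-type nitrogen also tolerates a new pattern, with both a 1.4-fold higher number from compound 2 to compound 4 (0.16 log units; within the scatter) and a 1.8-fold higher number from compound 1 to compound 4 (0.25 log units; within the scatter) within the scatter, so 2-chloro-4-methylphenyl, 4-propoxyphenyl and 4-iodophenyl cannot be told apart here. Nothing available explains these results.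

As far as these compounds go, whether the aromatic ring is needed at all, or a plain primary amide or a carboxylic acid on the same chain carbon would serve as well, stays open. So does the effect of a longer chain between the sulfur and the amide.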